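3-Hydroxyphenyl to 4-methylphenyl on compound 2

The compounds below may be only part of what the source reports. "The series", "measured", "known", "first", "only" and "open" are said of these compounds alone.

Compound 1 `CN(C)C(=O)c1cc2cnc(Nc3ccc(N)cn3)nc2n1C1CCCC1` gives 68%
Compound 2 `CN(C)C(=O)c1cc2cnc(Nc3ccc(NC(=O)C4(C(=O)Nc5cccc(O)c5)CC4)cc3)nc2n1C1CCCC1` gives 86%
Compound 3 `CN(C)C(=O)c1cc2cnc(Nc3ccc(NC(=O)C4(C(=O)Nc5ccccc5F)CC4)cc3)nc2n1C1CCCC1` gives 82.6%

In a functional assay on OVCAR-5 cells (Homo sapiens) for inhibition, read by CCK-8 assay, with a stated time of 72 h, tested at 10 uM (on this read-out higher numbers stand for more inhibition of growth at the one concentration tested and lower numbers for less inhibition of growth), compound 2 gives 86% and stands clearly over compound 1, while compound 2 and compound 3 lie within the scatter of each other. Compound 4 `Cc1ccc(NC(=O)C2(C(=O)Nc3ccc(Nc4ncc5cc(C(=O)N(C)C)n(C6CCCC6)c5n4)cc3)CC2)cc1` is not yet measured. It differs from compound 2 on an amide-type nitrogen, where 4-methylphenyl takes the place of 3-hydroxyphenyl 4-methylphenyl in place of 3-hydroxyphenyl on an amide-type nitrogen and nothing else changes. Going by the values given here, one measured step bears on this place, a number 3.4 percentage points lower from compound 2 to compound 3 (within the scatter) with 2-fluorophenyl in place of 3-hydroxyphenyl. On that single step, no change beyond the scatter is expected in this assay and any drift is expected to be slightly downward. The expected step is a number 4 percentage points lower from compound 2 to compound 4 (within the scatter) as an estimate. Compound 4 is estimated at 82% with an expected range from 71% to 92% for its measurement.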

Compound 4, percent growth inhibition at one concentration: 80.6%
Beside the measured number, compound 4's estimate is 1.4 percentage points above it; the measured number falls inside the stated range.
By their numbers in this assay, from the lowest: compound 1; then compounds 4, 3 and 2 (each within the scatter of the next).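

In this assay, the change from 3-hydroxyphenyl to 4-methylphenyl on the amide-type nitrogen reads a number 5.4 percentage points lower from compound 2 to compound 4 (within the scatter), and the change from 2-fluorophenyl to 4-methylphenyl reads a number 2 percentage points lower from compound 3 to compound 4 (within the scatter). So 4-methylphenyl, with 0 hydrogen-bond donors and 0 hydrogen-bond acceptors, gives a number within the scatter of those for the 3-hydroxyphenyl and 2-fluorophenyl compounds. No measurement here offers an explanation for this. Going by these compounds, whether an amine or a carboxylic acid on this phenyl ring would give a similar number remains open. So does whether these compounds would separate at lower concentrations.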